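A few compounds are considered here, and "the series" means these few. Any claim that something is new, unique, unknown or untested is made for them only; others in the source may bear on it.

Measured so far in a functional assay on CAKI-1 cells (Homo sapiens) for cytotoxicity, read by sulforhodamine B assay, with a stated time of 48 h; on this read-out higher numbers stand for weaker inhibition of growth and lower numbers for stronger inhibition of growth:
- compound 1, `CC1=C(C(=O)Nc2ccc(F)c(Cl)c2)C(c2ccccc2Cl)NC(=S)N1`: 31600 nM
- compound 2, `CC1=C(C(=O)Nc2ccc(F)c(Cl)c2)C(c2cccc(Oc3ccccc3)c2)NC(=S)N1`: 12600 nM
- compound 3, `CC1=C(C(=O)Nc2ccc(Cl)c(Cl)c2)C(c2cccc(Oc3ccccc3)c2)NC(=S)N1`: 8510 nM

Compound 1 gives the highest of the three numbers in this assay; compound 2 sits closer to it than compound 3 does, and both gaps to compound 1 are beyond the scatter. The difference between the cores of compound 1 and compound 2 is not broken down here.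

From compound 2 to compound 3 one change is made: chloro in place of fluoro on an aromatic carbon. The step that goes with it is a 1.5-fold lower number from compound 2 to compound 3 (0.17 log units; within the scatter), so within the scatter the two are not told apart.

Compound 4, `CC1=C(C(=O)Nc2ccc(Cl)c(Cl)c2)C(c2ccccc2Cl)NC(=S)N1`, is not yet measured in this assay. It relates to compound 1 by the same change, (chloro in place of fluoro on an aromatic carbon); the surroundings of the place are the same in words as for the pair compound 2 to compound 3, so this is the same change made on the other core, and it occurs two times among the compounds shown.

Resting on the step seen from compound 2 to compound 3, which stayed within the scatter, compound 4 is expected to give a number close to that of compound 1, estimated as a 1.4-fold lower number from compound 1 to compound 4 (0.16 log units; within the scatter). On this basis compound 4 is estimated at 22000 nM in this assay, expected to fall between 11000 nM and 45000 nM.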

Compound 4, concentration for 50% growth inhibition: 17800 nM
For compound 4 the middle estimate is 1.2-fold (0.09 log units) above the measured one; low and high end bracket the measured number.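

In this assay the change from 3-chloro-4-fluorophenyl to 3,4-dichlorophenyl on the core of compound 1 gives a 1.8-fold lower number from compound 1 to compound 4 (0.25 log units; within the scatter), so the two are not told apart on this read-out. Set beside the earlier step, the change carries from one core to the other with no difference that can be read: the same change on two cores in this assay, a 1.5-fold lower number (0.17 log units; within the scatter) from compound 2 to compound 3 and a 1.8-fold lower number (0.25 log units; within the scatter) from compound 1 to compound 4, 1.2-fold (0.08 log units) apart, within the scatter of two such steps. Among these compounds, this shows only that the change stays too small to read on both cores; it does not show that chloro gives a real gain over fluoro on either core, and two cores are too few to say how the change would behave on any core beyond those of compound 1 and compound 2.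

The compounds shown leave open whether another group at this place, such as a methoxy group, a nitrile or a carboxylic acid in place of the chloro, would give a step beyond the scatter. They also leave open what an amine or a longer alkyl chain at this place would do, and whether the steps seen here would look the same on another cell line.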